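Predicting the Cytotoxicity of Compound 4 From Three Neighbours

The compounds below may be only part of what the source reports. "The series", "measured", "known", "first", "only" and "open" are said of these compounds alone.

Measured so far:
compound 1, `COc1cccc(CNCCCNc2ccnc3cc(-c4ccc(C(F)(F)F)cc4)ccc23)c1O`, 2210 nM
compound 2, `COc1cccc(CNCCCNc2ccnc3cc(Cc4ccc(C#N)cc4)ccc23)c1O`, 7150 nM
compound 3, `COc1cccc(CNCCCNc2ccnc3cc(Cc4cc(C)cc(C)c4)ccc23)c1O`, 2680 nM

These three compounds share one core and were tested in an ADME assay on HepG2 cells (Homo sapiens) for cytotoxicity, read by luminescence, CellTiter-Glo and ATP content, with a stated time of 72 h; a higher number here means that more compound is needed for the effect, a lower number that less compound is needed. Among them, compound 1 gives the lowest number; compound 3 stands within the scatter of it, and compound 2 is the furthest away, with a 3.2-fold higher number from compound 1 to compound 2 (0.51 log units; beyond the scatter). The other two steps are a 1.2-fold higher number from compound 1 to compound 3 (0.08 log units; within the scatter) and a 2.7-fold lower number from compound 2 to compound 3 (0.43 log units; beyond the scatter).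

Compound 4, `COc1ccc(F)cc1CNCCCNc1ccnc2cc(-c3ccc(C(F)(F)F)cc3)ccc12`, has not yet been measured. It differs from compound 1 in one place: 5-fluoro-2-methoxyphenyl in place of 2-hydroxy-3-methoxyphenyl on a saturated chain carbon bound to an amine nitrogen. Every measured step changes the group on an aromatic carbon at a different part of the molecule, so none of them bears directly on this change. The two measured steps that go beyond the scatter are modest, and the remaining one lies within it, which suggests that single exchanges of this kind in this series tend to move the number only a little. Within the data shown here, with no direct precedent, the expectation for compound 4 is a step of a 1.1-fold higher number from compound 1 to compound 4 (0.05 log units; within the scatter), that is, no change beyond the scatter. Compound 4 is therefore estimated at 2500 nM, with a range from 900 nM to 7000 nM.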

Compound 4, half-maximal effective concentration: 5190 nM
Compound 4: middle estimate off by 2.1-fold (0.32 log units), on the low side; the range from low to high includes it.
By their numbers in this assay, from the lowest: compounds 1, 3, 4 and 2 (each within the scatter of the next, the first and the last beyond it).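

In this assay, the end of the molecule carrying the 2-hydroxy-3-methoxyphenyl group proves able to shift the number: putting 5-fluoro-2-methoxyphenyl in its place on the saturated chain carbon bound to an amine nitrogen gives a 2.3-fold higher number from compound 1 to compound 4 (0.37 log units; beyond the scatter), so more compound is needed for the effect. Among these compounds, the earlier steps all changed the group on an aromatic carbon at another part of the molecule, so this is the first sign that this place matters too, though only modestly. The exchange alters several things at once, since the hydroxyl goes, a fluorine arrives, and the count falls from 1 hydrogen-bond donor and 2 acceptors to 0 donors and 1 acceptor, and nothing available here explains the rise in the number.

The compounds shown leave open which of these alterations carries the step, as no compound here changes only one of them. Also open, as far as these compounds go, is how this place would respond to a plain unsubstituted phenyl group or a carboxylic acid on that ring, and whether the same exchange would give a similar step on the cores of compound 2 and compound 3.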